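A few compounds are considered here, and "the series" means these few. Any claim that something is new, unique, unknown or untested is made for them only; others in the source may bear on it.

Compound 3 `O=C(/C=C/c1cccc(NS(=O)(=O)c2ccc(Cl)cc2)c1)c1nc2ccccc2[nH]1` has the highest number of the three in a functional assay on 143B cells (Homo sapiens) for antiproliferative activity, read by MTT assay, with a stated time of 48 h (on this read-out lower numbers stand for stronger inhibition and higher numbers for weaker inhibition), at 7450 nM, though its gap to compound 2 is within the scatter. Compound 2 `COc1ccc(C(=O)Nc2cccc(/C=C/C(=O)c3nc4ccccc4[nH]3)c2)cc1` gives 6330 nM, and compound 1 `O=C(Nc1cccc(/C=C/C(=O)c2nc3ccccc3[nH]2)c1)c1cccc(Cl)c1` gives 3370 nM. The step of a 1.2-fold higher number from compound 2 to compound 3 (0.07 log units; within the scatter) stays within the scatter, while a 2.2-fold higher number from compound 1 to compound 3 (0.34 log units; beyond the scatter) is modest. Compound 4 `O=C(/C=C/c1cccc(NS(=O)(=O)c2cc(Cl)cc(Cl)c2)c1)c1nc2ccccc2[nH]1` differs from compound 3 by 3,5-dichlorophenyl in place of 4-chlorophenyl on a sulfonyl sulfur. Going by the values given here, no measured step changes the ring on the sulfonyl sulfur itself. The nearest comparison is a 1.9-fold higher number from compound 1 to compound 2 (0.27 log units; within the scatter), an exchange of one substituted ring for another on a carbonyl carbon, which stayed within the scatter. Compound 4 is therefore expected to show little change, a 1.1-fold lower number from compound 3 to compound 4 (0.03 log units; within the scatter). Compound 4 is estimated at 7000 nM, with a range from 3000 nM to 16000 nM.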

Compound 4, half-maximal inhibitory concentration: 5950 nM
Compound 4: the middle estimate sits 1.2-fold (0.07 log units) above what was measured; low and high end bracket the measured number.
By their numbers in this assay, from the lowest: compounds 1, 4, 2 and 3 (each within the scatter of the next, the first and the last beyond it).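

In this assay, going by these compounds alone, compound 3 and compound 4 are the only pair here that differ in the ring on the sulfonyl sulfur, and 3,5-dichlorophenyl in place of 4-chlorophenyl gives a 1.3-fold lower number from compound 3 to compound 4 (0.10 log units; within the scatter). At this position, then, the two chlorophenyl rings cannot be told apart by this read-out. Nothing available bears on this result.

The step alters both the number of chlorines and where they sit, so the two changes cannot be separated. As far as these compounds go, whether an amine or a carboxylic acid on this ring would give a step beyond the scatter remains open.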